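Methylsulfanyl to Methylsulfonyl on the Shared Core

The compounds below may be only part of what the source reports. "The series", "measured", "known", "first", "only" and "open" are said of these compounds alone.

Compound 1 `FC(F)(F)c1ccc(Nc2ncnc3sc(Nc4c(Cl)cccc4Cl)nc23)cc1Cl` gives 9 nM in a functional assay on HEK293 cells for antagonist activity at transient receptor potential cation channel subfamily V member 1 (Rattus norvegicus), read by calcium flux; on this read-out higher numbers stand for weaker inhibition and lower numbers for stronger inhibition. For the measured compounds named here, compound 2 `CSc1nc(Nc2ccc(C(F)(F)F)c(Cl)c2)c2nc(Nc3c(Cl)cccc3Cl)sc2n1` gives 113 nM in this assay, the higher of the two numbers measured so far, and the only recorded step, a 13-fold higher number from compound 1 to compound 2 (1.10 log units; beyond the scatter), is a large one. Compound 3 `CS(=O)(=O)c1nc(Nc2ccc(C(F)(F)F)c(Cl)c2)c2nc(Nc3c(Cl)cccc3Cl)sc2n1` differs from compound 2 by methylsulfonyl in place of methylsulfanyl on an aromatic carbon, at the position described as between two ring nitrogen atoms. Going by the values given here, no measured step bears directly on this exchange; the one known step concerns the same position and shows a large loss of inhibition when methylsulfanyl replaces hydrogen, but it gives no direction for swapping methylsulfanyl for methylsulfonyl. The expectation therefore stays near compound 2, leaning slightly weaker. Compound 3 is expected at 250 nM in this assay, within a range of 60 nM to 1000 nM. This corresponds to an expected step of a 2.2-fold higher number from compound 2 to compound 3 (0.34 log units; beyond the scatter).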

Compound 3, half-maximal inhibitory concentration: 77 nM
The estimate for compound 3 lay 3.2-fold (0.51 log units) above the measured number, and the stated range covers the measured number.
By their numbers in this assay, from the lowest: compound 1; then compounds 3 and 2 (each within the scatter of the next).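

At the position between two ring nitrogen atoms, methylsulfonyl and methylsulfanyl cannot be told apart in this assay: the exchange gives a 1.5-fold lower number from compound 2 to compound 3 (0.17 log units; within the scatter) and so adds two oxygen atoms with no change beyond the scatter. The step from hydrogen, an 8.6-fold higher number from compound 1 to compound 3 (0.93 log units; beyond the scatter), shows that the earlier loss of inhibition was not confined to methylsulfanyl, since both sulfur groups at this position lie beyond the scatter from hydrogen. Nothing given here explains why the two sulfur groups read alike or why either differs from hydrogen.

Only hydrogen and these two sulfur groups are shown at this position, so it remains open whether a small group without sulfur, such as an amine or a methoxy group, would stay close to hydrogen. From the compounds shown here alone, it is also open how a longer chain on the sulfur, such as ethylsulfonyl, would read.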